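Z and E pair: replacing the 4-pentylphenyl group

The source may hold more compounds than are shown below. What is called first, only, known or untested is meant among the compounds shown, and "the series" means these compounds.

Values in a functional assay on L1210 cells (Mus musculus) for antiproliferative activity, read by MTT assay, with a stated time of 2 days; a higher number here means a weaker inhibitor, a lower number a stronger inhibitor:
- compound 1 `CCCCCc1ccc(C#Cc2cn(C/C=C\CN3C(=O)c4ccccc4C3=O)c(=O)[nH]c2=O)cc1`: 28000 nM
- compound 2 `CCCCCc1ccc(C#Cc2cn(C/C=C/CN3C(=O)c4ccccc4C3=O)c(=O)[nH]c2=O)cc1`: 39000 nM

Compound 2 stands within the scatter of compound 1. Compound 3 `CCCCC#Cc1cn(C/C=C/CN2C(=O)c3ccccc3C2=O)c(=O)[nH]c1=O` carries butyl in place of 4-pentylphenyl on a triple-bonded carbon. Among the compounds with values here, the only measured step, a 1.4-fold higher number from compound 1 to compound 2 (0.14 log units; within the scatter), rests on the fact that compounds 1 and 2 differ only in the configuration as drawn and leaves that group untouched, so it gives no size for this change. With no measured guide, the estimate stays close to compound 2 at 39000 nM, and the expected step, a 1.3-fold higher number from compound 2 to compound 3 (0.11 log units; within the scatter), lies within the scatter, with a wide range. For compound 3 the expected value in this assay is 50000 nM, with a range of 15000 nM to 150000 nM.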

Compound 3, half-maximal inhibitory concentration: 236000 nM
Beside the measured number, compound 3's estimate is 4.7-fold (0.67 log units) below it, and the stated range ends below it.
By their numbers in this assay, from the lowest: compounds 1 and 2 (each within the scatter of the next); then compound 3.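

In this assay, the group on a triple-bonded carbon is a place where the series responds: butyl in place of 4-pentylphenyl gives a 6.1-fold higher number from compound 2 to compound 3 (0.78 log units; beyond the scatter) and leaves a weaker inhibitor. The change removes the six-membered aromatic ring and shortens the group at once, so the step cannot be divided between the two. Nothing shown gives a cause for this step.

Open, going by these compounds, is whether plain phenyl or a longer chain such as octyl on that carbon would return towards compound 2. Also open, on these data alone, is whether the Z and E forms stay within the scatter of each other when butyl is present.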